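The compounds below may be only part of what the source reports. "The series", "measured", "known", "first", "only" and "open" are said of these compounds alone.

Compound 1 `c1ccc(NCc2ccc(CNc3ncccn3)cc2)cc1` gives 20% in a functional assay on the whole organism (strain C57BL/6L) for inhibition, with Mus musculus as the target, read by paw edema, with stated times of 30 min and 76 h, at a dose of 10 mg/kg by the intraperitoneal route; a higher number here means more inhibition at the dose given (going by the name of the read-out), a lower number less inhibition. Compound 2 `CSc1ccnc(NCc2ccc(CNc3ncc(F)cn3)cc2)n1` gives 20% in this assay, and compound 3 `Fc1cnc(NCc2ccc(CNc3nccc(C(F)(F)F)n3)cc2)nc1` gives 20%, so compound 1 stands level with both at the digits given. Within the data shown here, the one measured step, no change at the digits printed from compound 2 to compound 3 (within the scatter), lies within the scatter. Compound 4 `Clc1cccc(NCc2ccc(CNc3ncccn3)cc2)n1` differs from compound 1 in one place: 6-chloropyridin-2-yl in place of phenyl on an amine nitrogen. Among the measured compounds shown here, no measured pair changes the group on that amine nitrogen; the only step measured concerns a different part of the molecule and was flat, and all three values sit at one level. The step is therefore expected to stay within the scatter, no change at the digits printed from compound 1 to compound 4 (within the scatter). For compound 4 the estimate in this assay is 20%, with a range from 5% to 40%.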

Compound 4, a percentage reported as inhibition, in the whole organism at one dose (the size of the read-out at that dose, not a potency): > 50%
Compound 4 gave a limit, no number; the forecaster's own chance of this, stated with the estimate: 0%; at least 30 percentage points between middle value and limit.
By their numbers in this assay, from the lowest: compounds 1, 2 and 3 (each within the scatter of the next). At a limit, above all of these: compound 4.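

In this assay compound 4 reads > 50%, a limit and not a number. Placing 6-chloropyridin-2-yl instead of phenyl on the amine nitrogen gives a number at least 30 percentage points higher from compound 1 to compound 4 (beyond the scatter). This group on the amine nitrogen is therefore the first place in the series shown to move the read-out, whereas the earlier compounds stood at one level.

The change brings in a ring nitrogen and a chlorine together, and the compounds shown do not separate the two. A plain pyridin-2-yl or a chlorophenyl group on the same amine nitrogen would divide them.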